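Chloro for fluoro on the fused ring of compound 2

This account rests on a few compounds, and the source may have more. Where it says the series, first, only, none or still open, it means among the compounds named here.

Measured so far:
compound 1, `O=C(O)Cc1nn(Cc2nc3cccc(Cl)c3s2)c(=O)c2ccccc12`: 52%
compound 2, `O=C(O)Cc1nn(Cc2nc3cc(F)cc(F)c3s2)c(=O)c2ccccc12`: 80%

Of the compounds shown here, two have been tested in an in vivo functional assay on the whole organism for inhibition of sorbitol dehydrogenase (Rattus norvegicus), at a dose of 10 mg/kg by the oral route; a lower number here means less inhibition, a higher number more inhibition at the dose given (going by the name of the read-out). Compound 1 gives 52%, and compound 2 gives 80%. Of the two numbers, that of compound 2 is the higher; its distance to compound 1 lies beyond the usual scatter. For the measured compounds named here, no pair differing in a single place exists among the measured compounds, so no single-point step is known.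

The next compound, compound 3, is `O=C(O)Cc1nn(Cc2nc3cc(F)cc(Cl)c3s2)c(=O)c2ccccc12`. It is derived from compound 2 by one change: chloro in place of fluoro on an aromatic carbon. Compound 3 thus carries the same chloro group that compound 1 carries, with the fluoro group of compound 2 kept on the other position of the ring.

Since compound 1 with its chloro group gives 52% while compound 2 gives 80%, the step of a number 10 percentage points lower from compound 2 to compound 3 (within the scatter) is expected to be a modest decrease, possibly within the scatter. Compound 3 is therefore estimated at 70% in this assay, within a range from 50% to 90%.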

Compound 3, a percentage reported as inhibition, in the whole organism at one dose (the size of the read-out at that dose, not a potency): 58%
For compound 3 the middle estimate is 12 percentage points above the measured one; measured number inside the range.
By their numbers in this assay, from the lowest: compounds 1 and 3 (each within the scatter of the next); then compound 2.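

Chloro in place of fluoro on this aromatic carbon, ortho to a fused ring, is not a neutral exchange in this assay: it gives a number 22 percentage points lower from compound 2 to compound 3 (beyond the scatter). With chloro at this position, the second halogen makes no readable difference, since fluoro in place of hydrogen on the other aromatic carbon gives a number 6 percentage points higher from compound 1 to compound 3 (within the scatter); of the two single changes now linking these compounds, only the exchange of fluoro for chloro lies beyond the scatter. Nothing measured here bears on why this exchange lowers the read-out.

As far as these compounds go, it remains open whether the drop is specific to chloro or whether other groups on this aromatic carbon, such as methyl, methoxy or trifluoromethyl, would stay with compound 2 or fall with compound 3, and what hydrogen there would give with the fluoro group kept. A read-out from the whole organism at a single oral dose also leaves open whether the step reflects the inhibition of the enzyme itself or what happens to the compounds in the animal before they reach it.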